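Shrinking one ring in a compound at the assay limit

The source may report more compounds than this note shows. Statements on the series, on what has been measured and on what is new or still open speak of the compounds shown alone.

Values in a toxicity assay (LMTK cells) for cytotoxicity, with Mus musculus as the target, read by MTT assay, with a stated time of 72 h; a higher number here means a weaker inhibitor, a lower number a stronger inhibitor
compound 1 (`Cc1c(C)c2c(c(C)c1OC(=O)CCC(=O)O)CCC(C)(C(=O)NC1CC(C)(C)N([O])C(C)(C)C1)O2`) gives > 300000 nM
compound 2 (`CC1(C)CC(NC(=O)CCC(=O)O)CC(C)(C)N1[O]`) gives > 300000 nM
compound 3 (`Cc1c(C)c2c(c(C)c1OC(=O)CCC(=O)NC1CC(C)(C)N([O])C(C)(C)C1)CCC(C)(C(=O)NC1CC(C)(C)N([O])C(C)(C)C1)O2`) gives 133000 nM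

Compound 1 stands at the limit of > 300000 nM in this assay, at which 2 of the 3 values shown sit, and compound 2 is the other; each is a limit, not a number. Compound 4 (`Cc1c(C)c2c(c(C)c1OC(=O)CCC(=O)O)CCC(C)(C(=O)NC1CC(C)(C)N([O])C1(C)C)O2`) differs from compound 1 on an amide-type nitrogen: a group of 10 heavy atoms (8 carbon, 1 nitrogen, 1 oxygen; one five-membered non-aromatic ring with 1 hetero atom) in place of a group of 11 heavy atoms (9 carbon, 1 nitrogen, 1 oxygen; one six-membered non-aromatic ring with 1 hetero atom), on an amide-type nitrogen. Among the compounds with values here, the one measured step from compound 1 is an at least 2.2-fold lower number from compound 1 to compound 3 (0.35 log units; beyond the scatter). Within the data shown here, that step replaces one oxygen atom on a carbonyl carbon, a different place from the one that changes in compound 4. It therefore gives no reason to expect a change beyond the scatter in this assay. The expected change is a number no higher from compound 1 to compound 4 (the limit leaves the size open). The estimate for compound 4 is 300000 nM, with an expected range from 150000 nM to 600000 nM.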

Compound 4, half-maximal inhibitory concentration: > 300000 nM
Compound 4 ended at the assay's limit; the forecaster's own chance of this, stated with the estimate: 80%; the middle value sits exactly at the limit.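

Compound 4 gives > 300000 nM here, a limit and not a number. Within the data shown here, compound 1 also sits at a limit, so no step between compound 1 and compound 4 can be read. The compounds shown leave open whether the five-membered ring in place of the six-membered ring changes the value at all.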